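Changing one group on the chain of compound 2

A few compounds are considered here, and "the series" means these few. Any claim that something is new, unique, unknown or untested is made for them only; others in the source may bear on it.

Compound 1 `COCCCCCCCCCCCCCCC/C=C1/CC(CO)(COC(=O)C(C)(C)C)OC1=O`: 3.97 ug/mL as a measured number
Compound 2 `COC(=O)CCCCCCCCCCCCCC/C=C1\CC(CO)(COC(=O)C(C)(C)C)OC1=O`: > 10 ug/mL as a limit
Compound 3 `CCCCCCCCC(O)CCCCCC/C=C1\CC(CO)(COC(=O)C(C)(C)C)OC1=O`: > 10 ug/mL as a limit

All three compounds were tested in a functional assay on HL-60 cells (Homo sapiens) for antiproliferative activity (a higher number here means a weaker inhibitor of growth, a lower number a stronger inhibitor of growth), and only compound 1 returned a number. Compound 2 stands in this assay at > 10 ug/mL as a limit of the assay and not as a number. For the measured compounds named here, compound 3 shares that position, so the series so far shows the limit of > 10 ug/mL in this assay, at which 2 of the 3 values shown sit, as its most common result.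

Compound 4 `CC(C)(C)C(=O)OCCCCCCCCCCCCCCC/C=C1\CC(CO)(COC(=O)C(C)(C)C)OC1=O` differs from compound 2 in one place: (((tert-butyl)carbonyl)oxy)methyl in place of methoxycarbonyl on a saturated chain carbon, ten or more bonds along the chain from a double-bonded chain carbon. The exchange puts (((tert-butyl)carbonyl)oxy)methyl in place of methoxycarbonyl on a saturated chain carbon, ten or more bonds along the chain from a double-bonded chain carbon.

Going by the values given here, no measured pair shows this exchange on its own, so the data give no direct size for it. Compound 2 offers only its limit of > 10 ug/mL as a starting point for the expectation. No change beyond the usual scatter is therefore expected, and the estimated step of a number no higher from compound 2 to compound 4 (the limit leaves the size open) has no firm direction. Compound 4 may well return only a limit too. For compound 4 the estimated value is 10 ug/mL, with an expected range from 4 ug/mL to 25 ug/mL.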

Compound 4, concentration for 50% growth inhibition: 7.78 ug/mL
Compound 4: middle estimate off by 1.3-fold (0.11 log units), on the high side, and the stated range covers the measured number.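

In this assay compound 4 returns a number, 7.78 ug/mL, which shows that the chain can carry a group that gives a readable result in this series. Exchanging methoxycarbonyl for (((tert-butyl)carbonyl)oxy)methyl on the chain gives an at least 1.2-fold lower number from compound 2 to compound 4 (0.10 log units; that floor lies within the scatter), so the data set only a floor on the step, and that floor does not by itself separate the two compounds. The true size of the step stays open, since the starting point of compound 2 is a limit of the assay and not a number: the limit of > 10 ug/mL in this assay, at which 2 of the 4 values shown sit.

The compounds shown leave open whether the real step lies beyond the usual scatter, as that would take a measured number for compound 2 in place of its limit. They also leave open what this assay would return with a carboxylic acid, an amine or a free hydroxyl at the same place on the chain, or with a shorter or longer chain carrying the (((tert-butyl)carbonyl)oxy)methyl group.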